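Swapping One Side Chain on a Shared Core

The source may hold more compounds than are shown below. What is called first, only, known or untested is meant among the compounds shown, and "the series" means these compounds.

In a functional assay on U-87MG ATCC cells for inhibition, with U-87 MG (Homo sapiens) as the target, read by sulforhodamine B assay, with a stated time of 72 h (on this read-out lower numbers stand for stronger inhibition of growth and higher numbers for weaker inhibition of growth), compound 2 (`COc1ncc(-c2ccc3nccc(/C=C/C(=O)N4CCN(C)CC4)c3c2)cc1NS(=O)(=O)c1ccc(F)cc1F`) gives 220 nM. Among the compounds with values here, the only other measured compound, compound 1 (`COc1ncc(-c2ccc3nccc(/C(C)=C/C(=O)N(C)CCO)c3c2)cc1NS(=O)(=O)c1ccc(F)cc1F`), gives 380 nM, and these two numbers lie within the scatter of each other. Compound 3 (`COc1ncc(-c2ccc3nccc(/C(C)=C\C(=O)N4CCOCC4)c3c2)cc1NS(=O)(=O)c1ccc(F)cc1F`) keeps the shared core but carries a different side chain: 1-methyl-2-((morpholin-4-yl)carbonyl)ethenyl in place of 2-((4-methylpiperazin-1-yl)carbonyl)ethenyl on an aromatic carbon. Within the data shown here, the one measured step that bears on this is a 1.7-fold lower number from compound 1 to compound 2 (0.24 log units; within the scatter). That step also exchanged the amide part and the methyl on the ethenyl linker together, yet it stayed within the scatter. Among the measured compounds shown here, no compound with the morpholin-4-yl group has been measured, so this guide is indirect. On the evidence of compound 1 and compound 2, no change beyond the scatter is expected in this assay. The expected step is a 1.6-fold higher number from compound 2 to compound 3 (0.20 log units; within the scatter). Compound 3 is estimated at 350 nM, with an expected range of 110 nM to 1000 nM.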

Compound 3, concentration for 50% growth inhibition: > 10000 nM
Compound 3 ended at the assay's limit (the forecaster's own chance of this, stated with the estimate: 3%); middle value at least 28-fold (1.45 log units) away from the limit.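

In this assay this position on the shared core proves far less tolerant than the first two compounds suggested: replacing the side chain gives an at least 45-fold higher number from compound 2 to compound 3 (1.65 log units; beyond the scatter), and the comparison with the other methyl-bearing side chain gives an at least 26-fold higher number from compound 1 to compound 3 (1.42 log units; beyond the scatter). Both steps lie beyond the scatter, whereas the earlier pair stayed within it, so these amide side chains are clearly not interchangeable here. Compound 3 stands at a limit of the assay rather than at a true number, so both steps give only a minimum size: the limit of > 10000 nM in this assay, at which 1 of the 3 values shown sits.

Compound 1 and compound 3 both carry the methyl on the ethenyl linker but are drawn with opposite geometry about its double bond, so the part played by the morpholin-4-yl group and the part played by that geometry remain unseparated. On these data alone, whether a primary amide or a piperidine amide on the same linker would restore growth inhibition also remains open.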